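Shortening the Phenoxybutyl Chain of Compound 3

The source may report more compounds than this note shows. Statements on the series, on what has been measured and on what is new or still open speak of the compounds shown alone.

In a functional assay on PC-3 cells (Homo sapiens) for antiproliferative activity, read by MTT assay, with a stated time of 48 h (on this read-out higher numbers stand for weaker inhibition of growth and lower numbers for stronger inhibition of growth), compound 3 `Cc1ccc(-c2cnc(N(CCCCOc3ccccc3)Cc3ccc(C(=O)NO)cc3)s2)cc1` gives 10300 nM, level with compound 2 `Cc1ccc(-c2cnc(N(Cc3ccccc3)Cc3ccc(C(=O)NO)cc3)s2)cc1` at 10400 nM, while compound 1 `CCCCCN(Cc1ccc(C(=O)NO)cc1)c1ncc(-c2ccc(C)cc2)s1` gives 5060 nM. Compound 4 `CCCN(Cc1ccc(C(=O)NO)cc1)c1ncc(-c2ccc(C)cc2)s1` changes only the chain: hydrogen in place of phenoxymethyl on a saturated chain carbon, three bonds along the chain from a nitrogen on an aromatic ring. Read another way, this is 4-phenoxybutyl to propyl, which leaves a plain chain like the pentyl chain of the core of compound 1. The closest guide is therefore a 2.0-fold higher number from compound 1 to compound 3 (0.31 log units; beyond the scatter), a modest step, read in reverse. Swapping one ring-bearing chain for another gave a 1.0-fold lower number from compound 2 to compound 3 (0.00 log units; within the scatter), so it offers little guidance here. In this assay, a modest step to a lower number is expected, with a 1.9-fold lower number from compound 3 to compound 4 (0.27 log units; within the scatter). The estimated value for compound 4 is 5500 nM, within a range from 2300 nM to 11000 nM.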

Compound 4, concentration for 50% growth inhibition: 9160 nM
Compound 4: middle estimate off by 1.7-fold (0.22 log units), on the low side; low and high end bracket the measured number.
By their numbers in this assay, from the lowest: compounds 1, 4, 3 and 2 (each within the scatter of the next, the first and the last beyond it).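

In this assay, removing phenoxymethyl from this chain leaves the number essentially unmoved, with a 1.1-fold lower number from compound 3 to compound 4 (0.05 log units; within the scatter) and with a 1.1-fold lower number from compound 2 to compound 4 (0.06 log units; within the scatter) as well. The plain propyl chain also shows a 1.8-fold higher number from compound 1 to compound 4 (0.26 log units; within the scatter) and so lies within the scatter of all three earlier compounds, which means an aromatic ring on this chain is not needed for this level of growth inhibition. No available measurement accounts for this flat response. Open, going by these compounds, is whether an amine or a carboxylic acid at the chain end would shift the number, and whether a chain longer than pentyl would.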